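Chloro Added to the Sulfanyl Arm of Compound 2

The source may report more compounds than this note shows. Statements on the series, on what has been measured and on what is new or still open speak of the compounds shown alone.

Measured compounds:
Compound 1, `Cn1c(-c2ccc(NC(=O)CCl)cc2)nc(-c2ccccc2)c1-c1ccccc1`: 28.7 ug/mL
Compound 2, `Cn1c(-c2ccc(NC(=O)CSc3nc4ccccc4o3)cc2)nc(-c2ccccc2)c1-c1ccccc1`: 11 ug/mL

In a functional assay on HT-29 cells (Homo sapiens) for cytotoxicity, read by MTT assay, with a stated time of 24 h (a higher number here means a weaker inhibitor, a lower number a stronger inhibitor), compound 1 gives 28.7 ug/mL. In this assay, among the measured compounds shown here, compound 2 gives 11 ug/mL, the lowest of the two numbers; the only measured step is a 2.6-fold lower number from compound 1 to compound 2 (0.42 log units; beyond the scatter). Compound 3, `Cn1c(-c2ccc(NC(=O)CSc3nc4cc(Cl)ccc4o3)cc2)nc(-c2ccccc2)c1-c1ccccc1`, differs from compound 2 by chloro in place of hydrogen on an aromatic carbon. No measured step touches this fused ring, so nothing shown bears directly on it; the single known step concerns the group entering at the chain carbon, not a substituent on its ring. Compound 3 is therefore expected to move little, a 1.2-fold lower number from compound 2 to compound 3 (0.09 log units; within the scatter), within the scatter. Compound 3 is estimated at 9 ug/mL, from 4 ug/mL to 22 ug/mL.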

Compound 3, half-maximal inhibitory concentration: 20.6 ug/mL
Beside the measured number, compound 3's estimate is 2.3-fold (0.36 log units) below it; the measured number falls inside the stated range.
By their numbers in this assay, from the lowest: compounds 2, 3 and 1 (each within the scatter of the next, the first and the last beyond it).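

Among the compounds shown here, the first reading at this aromatic carbon of the fused system in this assay is a 1.9-fold higher number from compound 2 to compound 3 (0.27 log units; within the scatter) and so does not separate chloro from hydrogen there. The exchange at the chain carbon now reads a 1.4-fold lower number from compound 1 to compound 3 (0.14 log units; within the scatter) and thus, with the (5-chloro-1,3-benzoxazol-2-yl)sulfanyl group, does not repeat the step beyond the scatter seen with the (1,3-benzoxazol-2-yl)sulfanyl group. No evidence at hand offers a reason for either reading.

On these data alone, whether a methoxy group or an amine on this aromatic carbon would read differently stays open, as does the effect of chloro on the other carbons of that six-membered ring.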